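Dimethoxyphenyl to hydroxyphenyl: an outlook from two limits

The source may report more compounds than this note shows. Statements on the series, on what has been measured and on what is new or still open speak of the compounds shown alone.

Compound 1, `CC(C)N(Cc1cccc(OCCCCCC(=O)O)c1)C(=O)c1ccc(-c2ccncc2)cc1`, gives > 26000 nM in an ADME assay on Raji cells (Homo sapiens) for cytotoxicity, read by CellTiter-Glo and resazurin assay, with a stated time of 72 h; a lower number here means that less compound is needed, a higher number that more compound is needed for the effect; this value is a limit of the assay, not a number.
Compound 2, `COc1cc(OC)cc(-c2ccc(C(=O)N(Cc3cccc(OCCCCCC(=O)O)c3)C(C)C)cc2)c1`, gives > 26000 nM in this assay; this too is a limit.

Both compounds sit at the same limit (the limit of > 26000 nM in this assay, at which 2 of the 2 values shown sit), so the step that the two limits leave unreadable from compound 1 to compound 2 cannot be read. Compound 2 therefore stands only at a limit. Compound 3, `CC(C)N(Cc1cccc(OCCCCCC(=O)O)c1)C(=O)c1ccc(-c2cccc(O)c2)cc1`, differs from it in one place: 3-hydroxyphenyl in place of 3,5-dimethoxyphenyl on an aromatic carbon. For the measured compounds named here, no measured step bears readably on this change, so nothing beyond the scatter can be argued either way. Compound 3 is expected at 40000 nM, in the range 15000 nM to 120000 nM, an estimated step that the limit leaves unreadable from compound 2 to compound 3.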

Compound 3, half-maximal effective concentration: > 26000 nM
Compound 3: only a limit was reported (the forecaster's own chance of this, stated with the estimate: 80%); the middle value lies beyond the limit too.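

Compound 3 adds no readable step to compound 1 or compound 2, because all three stop at the same limit: the limit of > 26000 nM in this assay, at which 3 of the 3 values shown sit.
On these data alone, whether these three compounds differ at all in this assay stays open, and so does how the three aryl groups would rank.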